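Replacing the Amino Substituent on a Saturated Ring Carbon

A few compounds are considered here, and "the series" means these few. Any claim that something is new, unique, unknown or untested is made for them only; others in the source may bear on it.

Measured so far:
compound 1 `COC[C@H](NC1CCN(CCCc2c[nH]c3ccc(Cn4cncn4)cc23)CC1)c1ccc(F)cc1` gives 89%
compound 2 `COC[C@H](NC1CCN(CCCc2c[nH]c3ccc(-n4cnnc4)cc23)CC1)c1ccccc1` gives 93%
compound 3 `c1ccc(C2CCCCN2C2CCN(CCCc3c[nH]c4ccc(-n5cnnc5)cc34)CC2)cc1` gives 65%

Three compounds have been examined in a functional assay on CHO cells for activation of 5-hydroxytryptamine receptor 1D (Homo sapiens), read by GTPgammaS binding; on this read-out lower numbers stand for smaller maximal responses and higher numbers for larger maximal responses. Compound 2 stands at the top of the three numbers with 93%. Compound 1, with 89%, lies within the usual scatter of compound 2, so no order between these two can be claimed. Compound 3, at 65%, lies beyond the scatter below compound 2 and is the furthest of the three from it.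

Compound 4 `CN(Cc1cccs1)C1CCN(CCCc2c[nH]c3ccc(-n4cnnc4)cc23)CC1` has not yet been measured. It differs from compound 2 in one place: methyl((thiophen-2-yl)methyl)amino in place of (2-methoxy-1-phenylethyl)amino on a saturated ring carbon. Within the data shown here, no step between two measured compounds isolates a change of exactly this kind, so the expectation rests on the spread of the three numbers alone. The largest response of compound 2 leaves little room above it, and a moderate fall is expected, so that a number 15 percentage points lower from compound 2 to compound 4 (beyond the scatter) is the estimated step. Compound 4 is therefore expected to reach 78%, with a range from 60% to 95%.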

Compound 4, largest response reached (reported as efficacy), in percent of the reference or control that the assay uses: 81%
Estimate against measurement, compound 4: 3 percentage points below; the measured number falls inside the stated range.
By their numbers in this assay, from the lowest: compound 3; then compounds 4, 1 and 2 (each within the scatter of the next, the first and the last beyond it).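

In this assay, among these compounds, the first step that can be read at this position is a number 12 percentage points lower from compound 2 to compound 4 (beyond the scatter), with methyl((thiophen-2-yl)methyl)amino in place of (2-methoxy-1-phenylethyl)amino on the saturated ring carbon. Compound 4 keeps a sizeable response at 81%, even though the change removes the six-membered aromatic ring, the defined stereocentre and the hydrogen-bond donor of the group that leaves, all in one step. No measurement shown here accounts for the fall.

Among the compounds shown here, the single step cannot say which of these differences carries it. A (thiophen-2-yl)methylamino group, which keeps the hydrogen on the nitrogen, or a benzyl(methyl)amino group, which returns the six-membered aromatic ring, would each separate one of those differences from the rest.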